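Methoxy pattern on the pendant aryl: working notes

This account rests on a few compounds, and the source may have more. Where it says the series, first, only, none or still open, it means among the compounds named here.

Measured so far:
compound 1 `COc1cccc(-c2cc(-c3cc(C(C)C)c(O)cc3C)[nH]c(=O)c2C#N)c1` 49%
compound 2 `COc1ccc(-c2cc(-c3cc(C(C)C)c(O)cc3C)[nH]c(=O)c2C#N)c(OC)c1` 58%

Two compounds share the core and differ only in the methoxy pattern of the aryl group. In a functional assay for inhibition, tested at 100 ug/mL (on this read-out higher numbers stand for a stronger effect at the one concentration tested and lower numbers for a weaker effect), compound 1 gives 49% and compound 2 gives 58%. Within the data shown here, compound 2 holds the upper of the two numbers, yet the one step available, a number 9 percentage points higher from compound 1 to compound 2 (within the scatter), does not separate the two beyond the scatter, so neither compound can be called the more active.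

Compound 3 `COc1ccc(-c2cc(-c3cc(C(C)C)c(O)cc3C)[nH]c(=O)c2C#N)cc1` is not yet measured. It differs from compound 2 by hydrogen in place of methoxy on an aromatic carbon. Among the measured compounds shown here, the only measured step that bears on this change is the rearrangement of methoxy groups on the same ring, a number 9 percentage points higher from compound 1 to compound 2 (within the scatter), which stayed within the scatter. Removing one methoxy from the 2,4-dimethoxyphenyl of compound 2 is therefore expected to leave the read-out much where it is, with no shift beyond the scatter in either direction.

For compound 3 the expected value in this assay is 52%, within 35% to 70%. That expectation amounts to a step of a number 6 percentage points lower from compound 2 to compound 3 (within the scatter), which is no step beyond the scatter.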

Compound 3, a percentage reported as inhibition, at one concentration (the size of the read-out at that concentration, not a potency): 54%
Beside the measured number, compound 3's estimate is 2 percentage points below it, within the range that was stated.
By their numbers in this assay, from the lowest: compounds 1, 3 and 2 (each within the scatter of the next).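

In this assay, going from 2,4-dimethoxyphenyl to 4-methoxyphenyl gives a number 4 percentage points lower from compound 2 to compound 3 (within the scatter), so at this place, ortho to a large group, hydrogen in place of methoxy produces no step beyond the scatter. The single methoxy can also stand in either ring location seen so far: 4-methoxyphenyl in place of 3-methoxyphenyl gives a number 5 percentage points higher from compound 1 to compound 3 (within the scatter), and this read-out does not separate the two patterns. No supporting measurement is available to account for these small steps.

All three compounds carry at least one methoxy on the pendant aryl, so the compounds shown leave open what the read-out does when this ring has no methoxy at all, or when an amine or a carboxylic acid stands in its place. With a single tested concentration and all steps within the scatter, they also leave open whether any of these methoxy patterns gives a stronger or weaker effect at that concentration.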